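Swapping a hydroxy for a (3-chlorophenyl)amino group

The compounds below may be only part of what the source reports. "The series", "measured", "known", "first", "only" and "open" are said of these compounds alone.

- compound 1 `O=C(O)CCCCC(CCSC(=O)c1ccccc1)SC(=O)c1ccccc1`: 2.76%
- compound 2 `O=C(CCCCC1CCSS1)Nc1ccccc1Cl`: "not active" (no number reported)
- compound 3 `O=C(CCCCC(S)CCS)Nc1cccc(Cl)c1`: 3.22%

The measurements come from a functional assay on Bel-7402 cells (Homo sapiens) for inhibition, read by MTT assay, with a stated time of 24 h, tested at 10 ug/mL; a lower number here means less inhibition of growth, a higher number more inhibition of growth at the concentration tested. There, compound 1 gives 2.76% and compound 3 gives 3.22%. These two numbers lie within the usual scatter of each other, so compound 1 cannot be ranked apart from compound 3. Compound 2 has no number, being reported only as "not active" (no number reported).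

The next compound to be tested is compound 4 `O=C(CCCCC(CCSC(=O)c1ccccc1)SC(=O)c1ccccc1)Nc1cccc(Cl)c1`. It keeps the core of compound 1 and changes in one place: (3-chlorophenyl)amino stands in place of hydroxy on a carbonyl carbon ((3-chlorophenyl)amino in place of hydroxy on a carbonyl carbon).

Within the data shown here, no two measured compounds differ in just one place, so no measured step can guide the expectation directly. The closest clue is compound 3, which also has (3-chlorophenyl)amino on a carbonyl carbon and gives 3.22%. With this in mind, no change beyond the scatter is expected in this assay, though a slight upward drift is possible. The estimated size of the change is a number 3.2 percentage points higher from compound 1 to compound 4 (within the scatter). For compound 4, the estimated value is 6%, with an expected range from 0% to 25%.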

Compound 4, percent growth inhibition at one concentration: "not active" (no number reported)
Compound 4 has no reported number here, and the estimate cannot be compared.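

Among these compounds, compound 4 is reported only as "not active" in this assay, without a number, and no step from compound 1 to compound 4 can be read. Nothing given here explains this result. The compounds shown leave open whether (3-chlorophenyl)amino in place of hydroxy on the carbonyl carbon changes growth inhibition at all.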